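A few compounds are considered here, and "the series" means these few. Any claim that something is new, unique, unknown or untested is made for them only; others in the source may bear on it.

Compound 1 `C=C(C)COC[n+]1ccn(C)c1/C=N/O` gives -1.83
Compound 2 `C=CC(C)(C)OC[n+]1ccn(C)c1/C=N/O` gives -1.54
Compound 3 `CC#CC(C)OC[n+]1ccn(C)c1/C=N/O` gives -1.74

These numbers come from a physicochemical assay for lipophilicity (a lower number here means a more polar compound, a higher number a more lipophilic compound), and all lie within the scatter of one another. Compound 3 stands level with the other two, its steps being a number 0.09 log units higher from compound 1 to compound 3 (within the scatter) and a number 0.20 log units lower from compound 2 to compound 3 (within the scatter) on the measured scale. Compound 4 `C#CC(CC)OC[n+]1ccn(C)c1/C=N/O` has the same atoms as compound 3, joined differently, and the change is a group of 5 heavy atoms (5 carbon; no ring) in place of a group of 5 heavy atoms (5 carbon; no ring), on an oxygen on a saturated carbon on an oxygen on a saturated carbon. Two measured swaps at this place bear on it, a number 0.29 log units higher from compound 1 to compound 2 (within the scatter) and a number 0.20 log units lower from compound 2 to compound 3 (within the scatter) and neither goes beyond the scatter. No step beyond the scatter is therefore expected, and the estimated step is a number 0.01 log units lower from compound 3 to compound 4 (within the scatter) in this assay here. Compound 4 is estimated at -1.75 with an expected range from -2 to -1.5 as the upper end.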

Compound 4, distribution coefficient: -1.49
Compound 4: the middle estimate sits 0.26 log units below what was measured; the whole stated range lies below it.
By their numbers in this assay, from the lowest: compounds 1, 3, 2 and 4 (each within the scatter of the next, the first and the last beyond it).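

Rejoining the same atoms on the oxygen gives a number 0.25 log units higher from compound 3 to compound 4 (within the scatter) in this assay, and the swap from the 1,1-dimethylprop-2-en-1-yl group gives a number 0.05 log units higher from compound 2 to compound 4 (within the scatter) here. Within the data shown here, the swap from the 2-methylprop-2-en-1-yl group gives a number 0.34 log units higher from compound 1 to compound 4 (beyond the scatter) and is the first step at this position to pass the scatter, although it is a modest one. Nothing measured explains why these groups differ in this way.

The compounds shown leave open how this position would respond to a group carrying an amine or a carboxylic acid. A longer chain on the same oxygen also remains an open case.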